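The source may report more compounds than this note shows. Statements on the series, on what has been measured and on what is new or still open speak of the compounds shown alone.

In a functional assay on MCF7 cells (Homo sapiens) for cytotoxicity, read by CCK-8 assay, with a stated time of 48 h (on this read-out lower numbers stand for stronger inhibition and higher numbers for weaker inhibition), compound 1 `NS(=O)(=O)c1ccc(/N=C/c2c(Cl)c3ccccc3oc2=O)cc1` gives 120 nM and compound 2 `O=c1oc2ccccc2c(Cl)c1/C=N/c1ccc(S(=O)(=O)Nc2nccs2)cc1` gives 160 nM. Compound 3 `CC(C)(C)c1cc(C(C)(C)C)c2oc(=O)c(/C=N/c3ccc(S(N)(=O)=O)cc3)c(Cl)c2c1` gives 16 nM, the lowest of the three numbers, standing beyond the scatter from both of the others. Compound 4 `CC(C)(C)c1cc(C(C)(C)C)c2oc(=O)c(/C=N/c3ccc(S(=O)(=O)Nc4nccs4)cc3)c(Cl)c2c1` differs from compound 3 in a single place: 1,3-thiazol-2-yl in place of hydrogen on a sulfonamide nitrogen. The same change has been measured once before, on the core of compound 1, where it produced a 1.3-fold higher number from compound 1 to compound 2 (0.12 log units; within the scatter). One therefore expects no shift beyond the scatter here either, and the step is estimated as a 1.3-fold higher number from compound 3 to compound 4 (0.10 log units; within the scatter). Compound 4 is accordingly expected to give about 20 nM in this assay, with a likely range from 8 nM to 50 nM.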

Compound 4, half-maximal inhibitory concentration: 12 nM
The estimate for compound 4 lay 1.7-fold (0.22 log units) above the measured number; measured number inside the range.
By their numbers in this assay, from the lowest: compounds 4 and 3 (each within the scatter of the next); then compounds 1 and 2 (each within the scatter of the next).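

In this assay, the 1,3-thiazol-2-yl group on the sulfonamide nitrogen now proves to leave the number within the scatter on a second core as well: a 1.3-fold lower number from compound 3 to compound 4 (0.12 log units; within the scatter). The result no longer rests on the core of compound 1 alone, and the two steps agree within the scatter: the same change on two cores in this assay, a 1.3-fold higher number (0.12 log units; within the scatter) from compound 1 to compound 2 and a 1.3-fold lower number (0.12 log units; within the scatter) from compound 3 to compound 4, 1.8-fold (0.25 log units) apart, within the scatter of two such steps

The compounds shown carry only hydrogen or 1,3-thiazol-2-yl on this nitrogen. Going by these compounds, whether a methyl or acetyl group, or a pyridin-2-yl ring, would also leave the number unmoved stays open.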